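Swapping the distal aryl ring and watching cytotoxicity

The source may report more compounds than this note shows. Statements on the series, on what has been measured and on what is new or still open speak of the compounds shown alone.

This piece follows a small series built around a shared core, with a fixed ring system carrying a linker to an aryl ether whose outer ring is varied. Compound 1 `Cc1cn(C2CCN(Cc3cccc(Oc4cc(Cl)cc(Cl)c4)c3)CC2)c(=O)[nH]c1=O` is the reference point. In an ADME assay on MRC5 cells (Homo sapiens) for cytotoxicity, read by fluorescence and resazurin assay, with a stated time of 3 days (a higher number here means a weaker inhibitor, a lower number a stronger inhibitor), compound 1 gives 6730 nM. Two further compounds belong to the same family: compound 2 `Cc1cn(C2CCN(Cc3cccc(Oc4ccc(O)cc4)n3)CC2)c(=O)[nH]c1=O` and compound 3 `Cc1cn(C2CCN(Cc3cccc(Oc4cc(C(F)(F)F)cc(C(F)(F)F)c4)c3)CC2)c(=O)[nH]c1=O`. In this assay, among the measured compounds shown here, compound 2 gives "not determined" (no result reported) and compound 3 gives "not determined" (no result reported), so compound 1 holds the only number in this set, and nothing can be said of how it stands against its neighbours.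

The next compound to be measured is compound 4 `COc1cccc(Oc2cccc(CN3CCC(n4cc(C)c(=O)[nH]c4=O)CC3)c2)c1`. Compared with compound 1, its structure differs in one place: 3-methoxyphenyl in place of 3,5-dichlorophenyl on an oxygen on an aromatic ring

For the measured compounds named here, no pair of measured compounds shows how this assay responds to such a change, so the expected step rests on compound 1 alone. The step from compound 1 to compound 4 is estimated to be small, towards a weaker inhibitor, and not clearly beyond the usual scatter, which is what a 1.5-fold higher number from compound 1 to compound 4 (0.17 log units; within the scatter) expresses. On that basis compound 4 is expected to give about 10000 nM in this assay, most likely between 3500 nM and 30000 nM.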

Compound 4, half-maximal inhibitory concentration: 25300 nM
Estimate against measurement, compound 4: 2.5-fold (0.40 log units) below, within the range that was stated.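

With compound 4 the series gains its first readable step: in this assay, putting 3-methoxyphenyl in place of 3,5-dichlorophenyl on the oxygen gives a 3.8-fold higher number from compound 1 to compound 4 (0.58 log units; beyond the scatter), a modest move towards a weaker inhibitor. This shows that the outer ring of the aryl ether is not a silent position in this cell assay, at least for this one change. The two groups have the same heavy-atom count and the same kind of aromatic ring, so they differ in what that ring carries, but no measurement here accounts for the step.

Among the compounds shown here, a single pair cannot separate the loss of the chlorines from the arrival of the methoxy group, and the entries for compound 2 and compound 3 hold no number, so no step to either can be read. From the compounds shown here alone, it also stays open how this assay would respond to an outer ring carrying a single chlorine, or to an amine or a carboxylic acid in place of the methoxy group.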